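Changing the Propargyl Group of Compound 2

A few compounds are considered here, and "the series" means these few. Any claim that something is new, unique, unknown or untested is made for them only; others in the source may bear on it.

Compound 1 (`C#CCN(CC=C)C(=O)[C@@]1(c2ccsc2)C[C@H]1CN`) and compound 2 (`C#CCN(CCOC)C(=O)[C@@]1(c2ccsc2)C[C@H]1CN`) were both tested in an in vitro ADME assay on microsomes from liver (Homo sapiens) for metabolic stability; on this read-out higher numbers stand for fast clearance and lower numbers for slow clearance. Compound 1 gives < 2.6 mL/min/kg, which is a limit of the assay and not a number. Compound 2 gives < 2.6 mL/min/kg, which is also a limit. Among the measured compounds shown here, the only measured step, a step that the two limits leave unreadable from compound 1 to compound 2, therefore has no readable size, and the two compounds stand together at the limit of < 2.6 mL/min/kg in this assay, at which 2 of the 2 values shown sit.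

Compound 3 (`C=C(F)CN(CCOC)C(=O)[C@@]1(c2ccsc2)C[C@H]1CN`) differs from compound 2 in one place: 1-fluoroethenyl in place of ethynyl on a saturated chain carbon bound to an amide-type nitrogen. For the measured compounds named here, no measured step changes this ethynyl group, so the guidance is indirect and thin. With nothing pointing either way, no change beyond the usual scatter is expected in this assay, and clearance should stay slow. The estimated step is an at least 1.1-fold higher number from compound 2 to compound 3 (0.06 log units; that floor lies within the scatter). For compound 3 the estimated clearance is 3 mL/min/kg, with an expected range from 2 mL/min/kg to 7 mL/min/kg.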

Compound 3, clearance: < 2.6 mL/min/kg
Compound 3 gave a limit, no number (the forecaster's own chance of this, stated with the estimate: 55%); middle value at least 1.1-fold (0.06 log units) from the limit.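

Among the compounds shown here, compound 3 gives a limit in this assay and not a number, as compound 2 also does, so no step from compound 2 to compound 3 can be read. Still open, on these data alone, is how far the three compounds differ in clearance, and whether 1-fluoroethenyl in place of ethynyl changes it at all: the limit of < 2.6 mL/min/kg in this assay, at which 3 of the 3 values shown sit.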